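The compounds below may be only part of what the source reports. "The series", "measured", "known", "first", "only" and "open" are said of these compounds alone.

Compound 1 `CCCCCCCCC(CCO)n1cnc2c(OC)ncnc21`: 24600 nM
Compound 2 `CCCCCCCCC(CCO)n1cnc2c(N(C)C)ncnc21`: 21600 nM
Compound 3 `CCCCCCCCC(CCO)n1cnc2c(N)ncnc21`: not yet measured

Both values come from a functional assay on SW480 cells (Homo sapiens) for antiproliferative activity, read by MTT assay, with a stated time of 48 h; on this read-out higher numbers stand for weaker inhibition and lower numbers for stronger inhibition. Among the compounds with values here, compound 2 has the lowest of the two numbers, but it cannot be separated from compound 1, as the only measured step is a 1.1-fold lower number from compound 1 to compound 2 (0.06 log units; within the scatter). The next change is amino in place of dimethylamino on an aromatic carbon. That one step bears on it, since it also exchanges the group on an aromatic carbon. Within the data shown here, no measured compound yet carries amino there, so the evidence is thin. In this assay, among the measured compounds shown here, no shift beyond the scatter is expected, in either direction, because the one precedent is a 1.1-fold lower number from compound 1 to compound 2 (0.06 log units; within the scatter). The estimated step is a 1.1-fold lower number from compound 2 to compound 3 (0.03 log units; within the scatter). For compound 3 the expected value is 20000 nM, with an estimated range of 9000 nM to 40000 nM.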

Compound 3, half-maximal inhibitory concentration: 20700 nM
For compound 3 the middle estimate is 1.0-fold (0.01 log units) below the measured one, and the stated range covers the measured number.
By their numbers in this assay, from the lowest: compounds 3, 2 and 1 (each within the scatter of the next).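

In this assay, amino, with 1 hydrogen-bond donor and 1 heavy atom, replaces dimethylamino, with 0 donors and 3 heavy atoms, on this aromatic carbon, and the result is a 1.0-fold lower number from compound 2 to compound 3 (0.02 log units; within the scatter) for that exchange. Amino in place of methoxy gives a 1.2-fold lower number from compound 1 to compound 3 (0.07 log units; within the scatter), so a third group at this position still separates no pair among the three compounds. Nothing at hand speaks to why these groups cannot be told apart.

Still open, on these data alone, is whether a chloro or benzylamino group on this aromatic carbon would move the number beyond the scatter. Also open, as far as these compounds go, is whether a shorter chain, or a carboxylic acid in place of the terminal alcohol, would shift the values at all.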